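The source may hold more compounds than are shown below. What is called first, only, known or untested is meant among the compounds shown, and "the series" means these compounds.

In a functional assay on HEK293 cells for antagonist activity at transient receptor potential cation channel subfamily V member 1 (Rattus norvegicus), read by calcium flux (a higher number here means a weaker inhibitor, a lower number a stronger inhibitor), the measured compounds are these. Compound 1 `FC(F)(F)c1ccc(Nc2ncnc3sc(Nc4c(Cl)cccc4Cl)nc23)cc1` gives 3 nM. Compound 2 `FC(F)(F)c1ccc(Nc2ncnc3sc(Nc4ccccc4Cl)nc23)cc1` gives 32 nM. Compound 3 `O=C(c1ccc(Nc2ncnc3sc(Nc4c(Cl)cccc4Cl)nc23)cc1)N1CCCC1` reaches only a limit of the assay, > 5000 nM.

Compound 1 has the lowest number of the two that were measured, its nearest neighbour being compound 2. Compound 4 `FC(F)(F)c1ccc(Nc2ncnc3sc(Nc4c(Cl)cccc4Cl)nc23)cc1Cl` is not yet measured; it differs from compound 1 by chloro in place of hydrogen on an aromatic carbon. Both measured steps leave the shared core untouched: one is an 11-fold higher number from compound 1 to compound 2 (1.03 log units; beyond the scatter), the other at least 1600-fold higher number from compound 1 to compound 3 (3.22 log units; beyond the scatter), where compound 3 sits at the limit of > 5000 nM in this assay, at which 1 of the 3 values shown sits. Neither step adds a chloro, so they bear only loosely on this change. A small step is expected, no change at the digits printed from compound 1 to compound 4 (within the scatter). Compound 4 is estimated at 3 nM, within 0.8 nM to 12 nM.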

Compound 4, half-maximal inhibitory concentration: 9 nM
Beside the measured number, compound 4's estimate is 3.0-fold (0.48 log units) below it; measured number inside the range.
By their numbers in this assay, from the lowest: compound 1; then compound 4; then compound 2. At a limit, above all of these: compound 3.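

In this assay, chloro in place of hydrogen ortho to a trifluoromethyl group gives a 3.0-fold higher number from compound 1 to compound 4 (0.48 log units; beyond the scatter). Going by these compounds alone, this is the first reading at this position, which proves sensitive to a single added chlorine atom, though the step is modest and the direction is toward a weaker inhibitor. Nothing measured here accounts for the step.

Going by these compounds, whether a fluoro, methyl or methoxy group at this position would move the number further or less remains open. So does whether chloro here would have the same effect on compound 2.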